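The source may report more compounds than this note shows. Statements on the series, on what has been measured and on what is new or still open speak of the compounds shown alone.

Compound 1 `COC(=O)C1(c2ccc(Cl)cc2)CC1CN1CCN(c2ccccn2)CC1` gives 707 nM in an assay for displacement of a labelled ligand from Sigma non-opioid intracellular receptor 1 (Cavia porcellus); a lower number here means a stronger inhibitor, a higher number a weaker inhibitor.
Compound 2 `COC(=O)C1(c2ccc(N)cc2)CC1CN1CCN(c2ncccn2)CC1` gives > 10000 nM in this assay, which is a limit of the assay and not a number.

Going by the values given here, compound 2 stands at the limit of > 10000 nM in this assay, at which 1 of the 2 values shown sits; of the two measured values, it is the one that gives no number, while compound 1 gives a measured value. Compound 3 `COC(=O)C1(c2ccc(Cl)cc2)CC1CN1CCN(c2ncccn2)CC1` has not yet been measured. It differs from compound 2 in one place: chloro in place of amino on an aromatic carbon. The same chloro group is present in compound 1, but compound 1 and compound 2 also differ elsewhere, so no single step can be read between them. Since compound 1 gives 707 nM with the chloro group in place, compound 3 is expected to give a measured number rather than a limit. The step is expected to be an at least 6.6-fold lower number from compound 2 to compound 3 (0.82 log units; beyond the scatter), towards a lower number. Compound 3 is estimated at 1500 nM, with a range from 400 nM to 6000 nM.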

Compound 3, inhibition constant: 350 nM
The estimate for compound 3 lay 4.3-fold (0.63 log units) above the measured number; measured number outside the range, below it.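

In this assay, with the pyrimidin-2-yl group held fixed, changing 4-aminophenyl to 4-chlorophenyl gives an at least 28-fold lower number from compound 2 to compound 3 (1.45 log units; beyond the scatter), so the group on this aromatic ring has a large bearing on the read-out. The true size of that step remains open at one end, as the value for compound 2 is a limit of the assay and not a number: the limit of > 10000 nM in this assay, at which 1 of the 3 values shown sits.

With chloro kept in place, pyrimidin-2-yl in place of pyridin-2-yl on the ring amine nitrogen gives a 2.0-fold lower number from compound 1 to compound 3 (0.31 log units; beyond the scatter), a modest step compared with the first.

The compounds shown leave open whether the step comes from losing amino or from gaining chloro, and a fluoro, methyl or methoxy group at the same place could help separate the two. On these data alone, the methyl ester is the same throughout, so the effect of a carboxylic acid or an amide there also remains unknown.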